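The compounds below may be only part of what the source reports. "The series", "measured", "known", "first", "only" and "open" are said of these compounds alone.

So far, measurements exist for compound 1 `COc1ccc(C(Nc2cc(C)ccn2)c2ccc3cccnc3c2O)cc1O` and compound 2 `Oc1c(C(Nc2ccccn2)c2ccc(Cl)cc2)ccc2cccnc12`. In an assay for inhibition of protein disulfide-isomerase (Homo sapiens), with a stated time of 1 h (a lower number here means a stronger inhibitor, a higher number a weaker inhibitor), compound 1 gives 150 nM, and in this assay compound 2 gives 170 nM. Compound 2 holds the higher of these numbers, but its nearest neighbour is compound 1 and the gap between them lies within the usual scatter, so neither can be called the stronger inhibitor on this evidence.

Compound 3 `COc1cccc(C(Nc2ccccn2)c2ccc3cccnc3c2O)c1` has not yet been measured. It differs from compound 2 in one place: 3-methoxyphenyl in place of 4-chlorophenyl on a saturated chain carbon bound to an aromatic carbon and a nitrogen on an aromatic ring. Everything else in compound 2 is kept. Going by the values given here, no pair of measured compounds differs by this change alone, and compound 1 differs from compound 2 at more than one place, so its value cannot isolate the effect of this swap. With the evidence available, the step from compound 2 to compound 3 in this assay is expected to be small, a 1.5-fold higher number from compound 2 to compound 3 (0.17 log units; within the scatter), and not clearly beyond the scatter in either direction. Compound 3 is therefore estimated to give about 250 nM in this assay, with a likely range from 90 nM to 700 nM.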

Compound 3, half-maximal inhibitory concentration: 2860 nM
Compound 3: middle estimate off by 11-fold (1.06 log units), on the low side; measured number outside the range, above it.
By their numbers in this assay, from the lowest: compounds 1 and 2 (each within the scatter of the next); then compound 3.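

At the saturated chain carbon bound to an aromatic carbon and a nitrogen on an aromatic ring, the choice of substituted phenyl group matters a great deal in this assay: 3-methoxyphenyl in place of 4-chlorophenyl gives a 17-fold higher number from compound 2 to compound 3 (1.23 log units; beyond the scatter), a large step well beyond the scatter. Both groups contain one six-membered aromatic ring of carbon only, so the ring itself is kept, and the change lies in the substituent and where it is printed on that ring, with chlorine leaving and a methoxy oxygen entering as a hydrogen-bond acceptor. Nothing available here explains why this swap weakens inhibition so sharply.

Since the substituent and its ring position change together, this one step cannot show whether the loss follows the methoxy group, its place on the ring, or the departure of chlorine. 4-Methoxyphenyl and 3-chlorophenyl at this same place would separate these possibilities, while unsubstituted phenyl would show how the core behaves with neither substituent.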